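Lengthening the chain on the aromatic nitrogen

The source may report more compounds than this note shows. Statements on the series, on what has been measured and on what is new or still open speak of the compounds shown alone.

Compound 1, `O=C1Nc2ccccc2/C1=C\c1c(Cl)n(Cc2ccccc2)c2ccccc12`, gives 3630 nM in a functional assay on cells (Leukemia cell, Homo sapiens) for cytotoxicity, with a stated time of 48 h; on this read-out higher numbers stand for weaker inhibition of growth and lower numbers for stronger inhibition of growth.
Compound 2, `COc1cc2c(/C=C3/C(=O)Nc4cccc(Cl)c43)c(Cl)n(Cc3cc(OC)c(OC)c(OC)c3)c2cc1C`, gives 2450 nM in this assay.

Compound 1 holds the highest of the two numbers, but its gap to compound 2 stays within the scatter, so the two are read as equal. Among the measured compounds shown here, no pair of measured compounds differs in one place, so the series offers no measured step to lean on. Compound 3, `O=C1Nc2ccccc2/C1=C\c1c(Cl)n(CCCc2ccccc2)c2ccccc12`, differs from compound 1 by phenethyl in place of phenyl on a saturated chain carbon bound to an aromatic nitrogen. With nothing measured on such a lengthening, the step of a 1.1-fold lower number from compound 1 to compound 3 (0.05 log units; within the scatter) is expected to stay within the scatter, in no set direction. Compound 3 is estimated at 3200 nM, between 1200 nM and 8500 nM.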

Compound 3, concentration for 50% growth inhibition: 8910 nM
For compound 3 the middle estimate is 2.8-fold (0.44 log units) below the measured one, outside the stated range (above it).
By their numbers in this assay, from the lowest: compounds 2 and 1 (each within the scatter of the next); then compound 3.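

In this assay, among the compounds shown here, the change from benzyl to 3-phenylpropyl gives a 2.5-fold higher number from compound 1 to compound 3 (0.39 log units; beyond the scatter) and is the first step beyond the scatter. This place on the chain is therefore not indifferent to chain length, and here the longer chain goes with weaker inhibition of growth. No measurement available here bears on the reason for this step.

This single step leaves the shape of the trend open, including how a 2-phenylethyl chain or a longer chain would read. Also open, on these data alone, is whether an amine or a carboxylic acid in place of the phenyl ring would keep or reverse the loss.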